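The source may report more compounds than this note shows. Statements on the series, on what has been measured and on what is new or still open speak of the compounds shown alone.

Compound 1 `CCN(CC)c1ccc2cc(C(=O)NC3CC3)c(=O)oc2c1` gives > 100000 nM in a functional assay on HeLa cells (Homo sapiens) for cytotoxicity, read by MTT assay, with a stated time of 72 h (on this read-out higher numbers stand for weaker inhibition and lower numbers for stronger inhibition), which is a limit of the assay.
Compound 2 `O=C(NO)c1cc2ccc(OCc3ccccc3)cc2oc1=O` gives 31800 nM in this assay.
Compound 3 `CCN(CC)c1ccc2cc(C(=O)NN)c(=O)oc2c1` gives 5480 nM in this assay.

Compound 2 stands highest of the two numbers shown; its nearest neighbour is compound 3, with a lower number beyond the scatter. Compound 4 `NNC(=O)c1cc2ccc(OCc3ccccc3)cc2oc1=O` differs from compound 2 by amino in place of hydroxy on an amide-type nitrogen. Within the data shown here, the one measured step on the same kind of nitrogen is an at least 18-fold lower number from compound 1 to compound 3 (1.26 log units; beyond the scatter), where the starting point was a limit (the limit of > 100000 nM in this assay, at which 1 of the 3 values shown sits). That step put amino in place of cyclopropyl, not of hydroxy, so a smaller move in the same direction is expected here, a 4.0-fold lower number from compound 2 to compound 4 (0.60 log units; beyond the scatter). Compound 4 is estimated at 8000 nM in this assay, between 2000 nM and 30000 nM.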

Compound 4, half-maximal inhibitory concentration: > 100000 nM
Compound 4: only a limit was reported; the forecaster's own chance of this, stated with the estimate: 5%; middle value at least 12-fold (1.09 log units) from the limit.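

In this assay, amino in place of hydroxy on an amide-type nitrogen gives an at least 3.1-fold higher number from compound 2 to compound 4 (0.49 log units; beyond the scatter), the opposite direction to an at least 18-fold lower number from compound 1 to compound 3 (1.26 log units; beyond the scatter). Amino on this nitrogen therefore goes with a lower number in one pair and a higher number in the other, and these pairs differ in both the core and the group replaced. Compound 4 gives a limit, so its step has only a lower bound: the limit of > 100000 nM in this assay, at which 2 of the 4 values shown sit.

On these data alone, it remains open what hydroxy would give on the core of compound 1. Also open, as far as these compounds go, is how a methylamino group or a carboxylic acid would compare on the core of compound 2.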